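A few compounds are considered here, and "the series" means these few. Any claim that something is new, unique, unknown or untested is made for them only; others in the source may bear on it.

Among the measured compounds shown here, compound 2 `CC(=O)OCC(=O)N(O)C(C)c1ccc2oc(-c3ccccc3)cc2c1` stands at the lowest of the two numbers so far in an assay on RBL cells for inhibition of Polyunsaturated fatty acid 5-lipoxygenase (Rattus norvegicus) (a lower number here means a stronger inhibitor, a higher number a weaker inhibitor), where compound 2 gives 160 nM; its nearest neighbour is compound 1 `CC(=O)N(O)C(C)c1ccc2oc(-c3ccccc3)cc2c1`, which in this assay gives 490 nM. For the measured compounds named here, the single measured step between them, a 3.1-fold lower number from compound 1 to compound 2 (0.49 log units; beyond the scatter), concerns a change on the saturated chain carbon bound to the carbonyl carbon. Compound 3 `CC(c1ccc2oc(-c3ccccc3)cc2c1)N(O)C(N)=O` differs from compound 2 at the carbonyl carbon itself: amino in place of acetoxymethyl on a carbonyl carbon. Going by the values given here, no measured step alters the group on that carbon, so the step from compound 1 to compound 2 bears on it only loosely, as a sign that this assay answers modestly to changes close to the carbonyl. The acetoxymethyl group present in compound 2 but absent in compound 1 is lost, and what enters is a single nitrogen carrying a donor. The step from compound 2 to compound 3 is therefore expected to be a modest rise in number, a 1.6-fold higher number from compound 2 to compound 3 (0.19 log units; within the scatter), back toward the level of compound 1. Compound 3 is estimated at 250 nM in this assay, within a range from 70 nM to 900 nM.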

Compound 3, half-maximal inhibitory concentration: 410 nM
Compound 3: middle estimate off by 1.6-fold (0.21 log units), on the low side; low and high end bracket the measured number.
By their numbers in this assay, from the lowest: compound 2; then compounds 3 and 1 (each within the scatter of the next).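

In this assay, the carbonyl carbon whose other neighbour is the amide-type nitrogen now carries three measured groups, and only acetoxymethyl stands apart: there is a 2.6-fold higher number from compound 2 to compound 3 (0.41 log units; beyond the scatter) when amino replaces it, while there is a 1.2-fold lower number from compound 1 to compound 3 (0.08 log units; within the scatter) when amino replaces methyl. Compound 2 therefore remains the strongest inhibitor of the three, with its steps to both others beyond the scatter, and the exchange of methyl for amino gives no readable change, so amino does not share the gain seen with acetoxymethyl. Nothing measured here explains why acetoxymethyl alone separates from the other two groups.

The compounds shown leave open which part of the acetoxymethyl group goes with the lower number, as a hydroxymethyl or methoxymethyl group on this carbonyl carbon would be needed to separate the ester from the extended chain. From the compounds shown here alone, it also remains open how a methylamino or dimethylamino group would read here, and whether a plain ethyl or longer chain in that place would stay level with compounds 1 and 3 or move toward compound 2.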